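Following one methyl group through a liver microsome test

The compounds below may be only part of what the source reports. "The series", "measured", "known", "first", "only" and "open" are said of these compounds alone.

Measured so far in an ADME assay on microsomes from liver (Rattus norvegicus) for metabolic stability (a higher number here means that the compound lasts longer, a lower number that the compound disappears faster), for compounds that share a core:

Compound 1 `COc1ccc(Nc2cc3c(cn2)ncn3CC2CC2)c(OC)c1` gives < 0.0834 h as a limit
Compound 2 `Cc1nc2cc(Nc3cc4c(cn3)ncn4CC3CC3)ccc2o1` gives 0.167 h as a number
Compound 3 `CN1C(=O)COc2cc(Nc3cc4c(cn3)ncn4CC3CC3)ccc21` gives 0.317 h as a number

The reading for compound 1 is a limit of the assay and not a number. That leaves two true numbers, and those of compound 2 and compound 3 lie within the usual scatter of each other, so neither can be ranked over the other. No two of these compounds differ in one place only, so no single change has yet been measured on its own.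

Compound 4 `O=C1COc2cc(Nc3cc4c(cn3)ncn4CC3CC3)ccc2N1` differs from compound 3 in one place, with hydrogen in place of methyl on an amide-type nitrogen in a ring. Going by the values given here, no measured step covers this change. The expectation therefore starts from compound 3 at 0.317 h and allows for a modest step in this assay towards a longer half-life, one that would probably stay within the scatter. The estimated step is a 1.6-fold higher number from compound 3 to compound 4 (0.20 log units; within the scatter) and it is expected to be small. For compound 4 the estimated half-life is 0.5 h with an expected range from 0.2 h to 1.2 h in this test.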

Compound 4, half-life: 0.983 h
For compound 4 the middle estimate is 2.0-fold (0.29 log units) below the measured one; low and high end bracket the measured number.
By their numbers in this assay, from the lowest: compounds 2 and 3 (each within the scatter of the next); then compound 4. At a limit, below all of these: compound 1.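

In this assay, going by these compounds alone, the step from methyl to hydrogen on an amide-type nitrogen in a ring is the first single change in this set that can be read on its own, and it gives a 3.1-fold higher number from compound 3 to compound 4 (0.49 log units; beyond the scatter). This shows that the group at this place is not a silent bystander: with the rest of the molecule unchanged, losing one carbon atom and gaining the amide hydrogen is enough to separate the two half-lives by more than the usual scatter. Nothing on hand explains why the half-life changes at this position, so the result records what happens without saying how it happens.

The compounds shown carry only methyl and hydrogen at this place, so they leave open how an ethyl group, a longer chain or a chain ending in a carboxylic acid on that nitrogen would fare. Going by these compounds, it also stays open whether the same swap would have a similar effect in microsomes from human liver, or on a compound with a different group on the shared core.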